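Methylation of the Phenol in a Pyrazole Urea Series

The source may report more compounds than this note shows. Statements on the series, on what has been measured and on what is new or still open speak of the compounds shown alone.

Compound 1 `O=C(Nc1cccc(-n2cc(-c3ccncc3)c(-c3cc(O)cc(Cl)c3)n2)c1)Nc1ccc(Cl)c(C(F)(F)F)c1` is the higher of the two compounds measured in a functional assay on CAKI-1 cells (Homo sapiens) for inhibition, read by sulforhodamine B assay, with a stated time of 48 h, tested at 1 uM (a higher number here means a weaker effect of the compound at the concentration tested, a lower number a stronger effect), where compound 1 gives 98%. Compound 2 `O=C(Nc1cccc(-n2cc(-c3ccncc3)c(-c3cc(O)cc(Cl)c3)n2)c1)Nc1ccc(Cl)c(Cl)c1` gives 54% in this assay, so the change a number 44 percentage points lower from compound 1 to compound 2 (beyond the scatter) is large. Compound 3 `COc1cc(Cl)cc(-c2nn(-c3cccc(NC(=O)Nc4ccc(Cl)c(C(F)(F)F)c4)c3)cc2-c2ccncc2)c1` differs from compound 1 by methyl in place of hydrogen on an oxygen on an aromatic ring. Among the compounds with values here, no measured step concerns the hydroxy group, so the change from compound 1 to compound 2 offers no direct guide. The step of a number 6 percentage points lower from compound 1 to compound 3 (within the scatter) is therefore expected to stay within the scatter. Compound 3 is estimated at 92%, within 70% to 100%.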

Compound 3, a percentage reported as activity, at one concentration (the size of the read-out at that concentration, not a potency): 45%
The estimate for compound 3 lay 47 percentage points above the measured number, outside the stated range (below it).
By their numbers in this assay, from the lowest: compounds 3 and 2 (each within the scatter of the next); then compound 1.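

In this assay, the hydroxy to methoxy change gives a number 53 percentage points lower from compound 1 to compound 3 (beyond the scatter), so a single methyl on this oxygen of the 3-chloro-5-hydroxyphenyl group markedly strengthens the effect at the concentration tested. This position therefore matters as much in this assay as the trifluoromethyl site changed earlier, and the aromatic oxygen's hydrogen cannot be treated as a silent spot. No available measurement explains the step. From the compounds shown here alone, it remains open whether ethoxy or an amine at this place would act like methoxy, and whether methylation would also shift compound 2.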